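Hydrazide-linked adenosine analogues: a thiophene-to-isoxazole replacement

The compounds below may be only part of what the source reports. "The series", "measured", "known", "first", "only" and "open" are said of these compounds alone.

Of the compounds shown here, three have been measured in an assay on CHO cells for displacement of a labelled ligand from adenosine receptor A3 (Homo sapiens); a higher number here means a weaker inhibitor, a lower number a stronger inhibitor; every value reported is a limit of the assay rather than a number.
- compound 1 `CCNC(=O)[C@H]1O[C@@H](n2cnc3c(NNC(=O)c4ccc(Br)o4)ncnc32)[C@H](O)[C@@H]1O`: in this assay compound 1 gives > 5000 nM
- compound 2 `CCNC(=O)[C@H]1O[C@@H](n2cnc3c(NNC(=O)c4ccc(C)o4)ncnc32)[C@H](O)[C@@H]1O`: in this assay compound 2 gives > 5000 nM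
- compound 3 `CCNC(=O)[C@H]1O[C@@H](n2cnc3c(NNC(=O)c4cccs4)nc(Cl)nc32)[C@H](O)[C@@H]1O`: in this assay compound 3 gives > 5000 nM

Compound 3 thus stands at the limit, together with the other two, as summarised by the limit of > 5000 nM in this assay, at which 3 of the 3 values shown sit. Among the compounds with values here, the one measured single change, a step that the two limits leave unreadable from compound 1 to compound 2, is unreadable, since both ends sit at the limit, so no measured step gives a readable size for comparison.

Compound 4 `CCNC(=O)[C@H]1O[C@@H](n2cnc3c(NNC(=O)c4cc(C)on4)nc(Cl)nc32)[C@H](O)[C@@H]1O` differs from compound 3 by 5-methyl-1,2-oxazol-3-yl in place of thiophen-2-yl on a carbonyl carbon. Within the data shown here, no measured step bears on this change in a readable way. The expectation is therefore that compound 4 stays at the limit, with the step from compound 3 estimated as a step that the limit leaves unreadable from compound 3 to compound 4, which is not read as a direction beyond the scatter. Compound 4 is estimated at 8000 nM, within 2000 nM to 40000 nM.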

Compound 4, inhibition constant: > 5000 nM
Compound 4 ended at the assay's limit (the forecaster's own chance of this, stated with the estimate: 80%); the middle value is on the limit's open side.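

In this assay no step can be read between compound 3 and compound 4, since both values are limits of the assay: the limit of > 5000 nM in this assay, at which 4 of the 4 values shown sit.

Which change to the series, if any, gives a readable value remains open, as does how far each of the four compounds lies past the limit.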